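From 2-bromophenyl to 3-chlorophenyl at the assay's limit

A few compounds are considered here, and "the series" means these few. Any claim that something is new, unique, unknown or untested is made for them only; others in the source may bear on it.

Compound 3 `Brc1ccccc1CSc1nnc(-c2cnccn2)n1-c1ccccc1` sits at the edge of what a functional assay on HeLa cells (Homo sapiens) for antiproliferative activity, read by MTT assay, with a stated time of 48 h (a higher number here means a weaker inhibitor, a lower number a stronger inhibitor), can report. Compound 3 gives > 50000 nM, which is a limit and not a number. Compound 2 `Clc1ccccc1CSc1nnc(-c2cnccn2)n1-c1ccccc1` gives > 50000 nM, which is also a limit. Among the measured compounds shown here, the only true number here comes from compound 1 `Fc1ccccc1CSc1nnc(-c2cnccn2)s1`, at 32700 nM. The picture so far is dominated by the limit of > 50000 nM in this assay, at which 2 of the 3 values shown sit.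

Compound 4 `Clc1cccc(CSc2nnc(-c3cnccn3)n2-c2ccccc2)c1` keeps the shared core of compound 3 and changes only the benzyl part: 3-chlorophenyl in place of 2-bromophenyl on a saturated chain carbon bound to a sulfur. Put simply, 3-chlorophenyl stands in place of 2-bromophenyl on a saturated chain carbon bound to a sulfur, so 2-bromobenzyl becomes 3-chlorobenzyl.

For the measured compounds named here, the one measured step that bears on this is a step that the two limits leave unreadable from compound 2 to compound 3, with bromo in place of chloro on an aromatic carbon. Going by the values given here, its size cannot be read, and no measured step covers the change from 2-bromophenyl to 3-chlorophenyl. With no readable step to build on, no step beyond the scatter is expected in this assay. The expected step is a number no higher from compound 3 to compound 4 (the limit leaves the size open). Compound 4 is estimated at 50000 nM, with an expected range from 25000 nM to 100000 nM.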

Compound 4, half-maximal inhibitory concentration: 13500 nM
The estimate for compound 4 lay 3.7-fold (0.57 log units) above the measured number; measured number outside the range, below it.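

Among the compounds shown, this is the first change at this position, on a saturated chain carbon bound to a sulfur, that gives a readable result in this assay: there is an at least 3.7-fold lower number from compound 3 to compound 4 (0.56 log units; beyond the scatter), and also an at least 3.7-fold lower number from compound 2 to compound 4 (0.56 log units; beyond the scatter). The second step is the more telling one, since chlorine stays in the group and only the name changes from 2-chlorophenyl to 3-chlorophenyl, so a swap of halogen is not needed for a number to appear below the limit. Both sizes are only minimum sizes, and the step between the two 2-halophenyl compounds cannot be read, because those compounds carry a limit and not a number: the limit of > 50000 nM in this assay, at which 2 of the 4 values shown sit.

From the compounds shown here alone, what remains open is whether the drop belongs to chlorine itself or to any group placed as in 3-chlorophenyl, and a 3-bromophenyl or a 3-aminophenyl, which carries an amine, would help to separate those two readings. Going by these compounds, it is also open whether 3-chlorophenyl in place of 2-chlorophenyl would give a step of similar size on a different core.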